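Swapping a pyrrolidine for a chloropyridinyloxy group

The source may hold more compounds than are shown below. What is called first, only, known or untested is meant among the compounds shown, and "the series" means these compounds.

Measured so far:
Compound 1, `Cc1cc(Oc2ccc(Cl)cc2)c(S(C)(=O)=O)cc1C(=O)N=C(N)N`: 13 nM
Compound 2, `Cc1cc(N2CCCC2)c(S(C)(=O)=O)cc1C(=O)N=C(N)N`: 11 nM

Both compounds were tested in a functional assay for inhibition of sodium/hydrogen exchanger (Oryctolagus cuniculus); a higher number here means a weaker inhibitor, a lower number a stronger inhibitor. Compound 1 carries a 4-chlorophenoxy group on the shared core and gives 13 nM. Compound 2 carries pyrrolidin-1-yl at the same aromatic carbon and gives 11 nM. Among the measured compounds shown here, the only step measured so far, a 1.2-fold lower number from compound 1 to compound 2 (0.07 log units; within the scatter), lies within the scatter, so the two compounds cannot be told apart on these numbers and compound 2 does not stand apart from compound 1.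

Compound 3, `Cc1cc(Oc2cncc(Cl)c2)c(S(C)(=O)=O)cc1C(=O)N=C(N)N`, has not yet been measured. It differs from compound 2 in one place: (5-chloropyridin-3-yl)oxy in place of pyrrolidin-1-yl on an aromatic carbon

The entering group is an aryloxy bearing chlorine, and so resembles the 4-chlorophenoxy of compound 1 more than the pyrrolidin-1-yl of compound 2. For the measured compounds named here, the one relevant step, a 1.2-fold lower number from compound 1 to compound 2 (0.07 log units; within the scatter), shows that exchanging a chlorinated aryloxy for pyrrolidin-1-yl at this carbon changed little. Going back the other way toward a chlorinated aryloxy, the expected step is a 1.6-fold higher number from compound 2 to compound 3 (0.21 log units; within the scatter), a change that may not exceed the scatter. Compound 3 is therefore estimated at 18 nM in this assay, with a plausible range from 7 nM to 50 nM.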

Compound 3, half-maximal inhibitory concentration: 14 nM
Beside the measured number, compound 3's estimate is 1.3-fold (0.11 log units) above it; measured number inside the range.
By their numbers in this assay, from the lowest: compounds 2, 1 and 3 (each within the scatter of the next).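

In this assay, the step of a 1.3-fold higher number from compound 2 to compound 3 (0.10 log units; within the scatter) lies within the scatter, so at this aromatic carbon, ortho to a methylsulfonyl group, (5-chloropyridin-3-yl)oxy cannot be told apart from pyrrolidin-1-yl, even though it has more heavy atoms and a six-membered aromatic ring in place of a five-membered non-aromatic one. The other new comparison changes only the ring on the oxygen, and the step of a 1.1-fold higher number from compound 1 to compound 3 (0.03 log units; within the scatter) also lies within the scatter, so placing a ring nitrogen in the aryl group by using 5-chloropyridin-3-yl in place of 4-chlorophenyl gives no measurable difference here. Across these three compounds, then, one non-aromatic amine ring and two different chlorinated aryloxy groups at this carbon all give numbers that cannot be separated.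

No supporting measurement is available to explain why these three groups read alike. From the compounds shown here alone, it remains open whether the same would hold for a group of another kind at this carbon, such as a carboxylic acid, a primary amine or a longer alkyl chain.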